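Pyrazolyl for propylamino on a benzoyl amide

The source may report more compounds than this note shows. Statements on the series, on what has been measured and on what is new or still open speak of the compounds shown alone.

Measured so far:
- Compound 1 `Cc1cc(N)ccc1C(=O)N1CCCCc2cc(Cl)ccc21`: 4.1 nM
- Compound 2 `CCCNc1ccc(C(=O)N2CCCCc3ccccc32)c(Cl)c1`: 18 nM
- Compound 3 `O=C(c1ccc(N2CCCC2)cc1)N1CCCCc2cc(Cl)ccc21`: 210 nM

In an assay on HeLa cells for binding affinity to Vasopressin V2 receptor (Homo sapiens) (a lower number here means a stronger inhibitor, a higher number a weaker inhibitor), compound 2 gives 18 nM and stands second highest of the three numbers. Its nearest neighbour is compound 1, whose lower number lies beyond the usual scatter, so compound 1 is the stronger binder of the two. Its furthest neighbour is compound 3, whose higher number also lies beyond the scatter, so compound 2 binds more strongly than compound 3. None of these pairs differs in only one place, so the numbers show where each compound stands but not what any single change is worth.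

Compound 4 `Cc1ccn(-c2ccc(C(=O)N3CCCCc4ccccc43)c(Cl)c2)n1` has not yet been measured. It differs from compound 2 in one place: 3-methyl-1H-pyrazol-1-yl in place of propylamino on an aromatic carbon. The aromatic ring that enters replaces a flexible chain carrying a hydrogen-bond donor, on the carbon that sits meta to a chloro group and para to a large group. For the measured compounds named here, no measured pair shows this exact change, so its size in this assay is uncertain; a modest weakening is expected rather than a gain, since the only measured compound bearing a ring in place of a small amine, compound 3, sits at 210 nM. The step from compound 2 to compound 4 is expected to be a 1.9-fold higher number from compound 2 to compound 4 (0.29 log units; within the scatter). For compound 4 the estimate in this assay is 35 nM, with a range from 8 nM to 150 nM.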

Compound 4, half-maximal inhibitory concentration: 13 nM
Beside the measured number, compound 4's estimate is 2.7-fold (0.43 log units) above it, and the stated range covers the measured number.
By their numbers in this assay, from the lowest: compound 1; then compounds 4 and 2 (each within the scatter of the next); then compound 3.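

In this assay, the step on this aromatic carbon, meta to a chloro group and para to a large group, is a 1.4-fold lower number from compound 2 to compound 4 (0.14 log units; within the scatter), so compounds 2 and 4 cannot be told apart, even though the two groups differ considerably. Propylamino is an open chain with one hydrogen-bond donor, whereas 3-methyl-1H-pyrazol-1-yl brings a five-membered aromatic ring, two more heavy atoms and no donor, so in this one pair, binding to the receptor does not depend on keeping that donor or the chain. The earlier compounds could not show this, since none of them differed in only one place, and nothing measured here explains why the two numbers fall so close together.

This single pair cannot say whether the ring or its methyl group matters more, and a plain pyrazole, a phenyl ring or a longer chain on the same carbon would help to separate those parts. It also leaves open whether the same exchange would give a similar result on the core of compound 1 or compound 3.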